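Swapping Two Chlorines for Two Fluorines on a Weak Inhibitor

A few compounds are considered here, and "the series" means these few. Any claim that something is new, unique, unknown or untested is made for them only; others in the source may bear on it.

Three compounds have been measured in a functional assay on SK-MEL-5 cells (Homo sapiens) for inhibition, read by sulforhodamine B assay, with a stated time of 48 h; on this read-out lower numbers stand for stronger inhibition of growth and higher numbers for weaker inhibition of growth:

Compound 1 `COc1ccc(-c2cc(/C=C/C(=O)c3ccc(N)cc3)[nH]n2)cc1` gives 9250 nM
Compound 2 `COc1cc(-c2cc(/C=C/C(=O)c3ccc(N)cc3)[nH]n2)cc(OC)c1OC` gives 3060 nM
Compound 3 `COc1cc(-c2cc(/C=C/C(=O)c3ccc(Cl)c(Cl)c3)[nH]n2)cc(OC)c1OC` gives 46900 nM

Compound 3 stands highest of the three numbers, which on this read-out means the weakest growth inhibition. Its nearest neighbour is compound 1, and compound 2 lies furthest from it. Among the compounds with values here, the one measured step that reaches compound 3 is a 15-fold higher number from compound 2 to compound 3 (1.19 log units; beyond the scatter), a large move toward weaker inhibition when the aminophenyl on the carbonyl carbon was exchanged for a dichlorophenyl.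

Compound 4 `COc1cc(-c2cc(/C=C/C(=O)c3ccc(F)c(F)c3)[nH]n2)cc(OC)c1OC` is the next compound, and it differs from compound 3 only by 3,4-difluorophenyl in place of 3,4-dichlorophenyl on a carbonyl carbon. The ring on the carbonyl carbon keeps the same shape and the same count of atoms; only the kind of halogen changes. Within the data shown here, no measured pair shows an exchange of one halogen for another, so the single measured step gives no direct guide to its size or direction. It tells only that this position matters a great deal when the group changes its character entirely, which it does not do here.

The expected step is therefore small, a 1.2-fold lower number from compound 3 to compound 4 (0.07 log units; within the scatter), not beyond the scatter. Compound 4 is estimated at 40000 nM, with a range from 15000 nM to 110000 nM.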

Compound 4, concentration for total growth inhibition: 6410 nM
Compound 4: the middle estimate sits 6.2-fold (0.80 log units) above what was measured; the whole stated range lies above it.
By their numbers in this assay, from the lowest: compound 2; then compounds 4 and 1 (each within the scatter of the next); then compound 3.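

In this assay, the choice of halogen on this ring matters in its own right: the exchange gives a 7.3-fold lower number from compound 3 to compound 4 (0.86 log units; beyond the scatter), although the 3,4-difluorophenyl and the 3,4-dichlorophenyl have the same count of heavy atoms and neither carries a hydrogen-bond donor or acceptor. Within the data shown here, replacing the 4-aminophenyl on the carbonyl carbon with a halogen-bearing ring had so far been seen only as a large move toward weaker inhibition, but the difluorophenyl ring gives just a 2.1-fold higher number from compound 2 to compound 4 (0.32 log units; beyond the scatter), so the size of that loss depends on which halogen the new ring carries, while compound 2 with its 4-aminophenyl keeps the lower number. Nothing measured here explains why the two halogens differ so much, so the step stands as an observation only.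

Still open, as far as these compounds go, is how an unsubstituted phenyl or a 4-hydroxyphenyl would compare on this carbonyl carbon, which would show whether the halogens are needed at all. From the compounds shown here alone, it is equally open whether the exchange of chlorines for fluorines would give a step of similar size on the core of compound 1.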